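Swapping chloro for methyl on compound 2

The compounds below may be only part of what the source reports. "The series", "measured", "known", "first", "only" and "open" are said of these compounds alone.

In a functional assay on HT-29 cells (Homo sapiens) for antiproliferative activity, read by MTT assay, with a stated time of 72 h (a higher number here means a weaker inhibitor, a lower number a stronger inhibitor), compound 1 (`O=C1C=C(N2CCN(c3ccccc3Cl)CC2)C(=O)c2ccccc21`) gives 18900 nM and compound 2 (`O=C1C=C(N2CCN(c3ccccc3Cl)CC2)C(=O)c2c(O)cccc21`) gives 1400 nM as the lower of the two numbers. For the measured compounds named here, the only measured step is a 14-fold lower number from compound 1 to compound 2 (1.13 log units; beyond the scatter) for hydroxy in place of hydrogen on an aromatic carbon. It is large but concerns a different group, so it does not test the next change. Compound 3 (`Cc1ccccc1N1CCN(C2=CC(=O)c3cccc(O)c3C2=O)CC1`) differs from compound 2 by methyl in place of chloro on an aromatic carbon as methyl in place of chloro on an aromatic carbon, ortho to a large group. The estimated change is a 1.4-fold higher number from compound 2 to compound 3 (0.15 log units; within the scatter) and is expected to stay within the scatter. Compound 3 is expected near 2000 nM with a range from 800 nM to 5500 nM in this estimate.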

Compound 3, half-maximal inhibitory concentration: 2800 nM
Compound 3: the middle estimate sits 1.4-fold (0.15 log units) below what was measured; the range from low to high includes it.
By their numbers in this assay, from the lowest: compounds 2 and 3 (each within the scatter of the next); then compound 1.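

In this assay methyl in place of chloro, ortho to a large group, gives a 2.0-fold higher number from compound 2 to compound 3 (0.30 log units; within the scatter) and so does not separate the two groups. Compounds 1 and 2 both carry chloro, so only now is it clear that chloro is not required at this place for a number in this range. Nothing measured here offers an explanation for this result. On these data alone, whether a methoxy group or an amine at this place would move the number beyond the scatter remains open. So does whether the same swap would read alike on compound 1, which lacks the hydroxy.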